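The compounds below may be only part of what the source reports. "The series", "measured", "known", "first", "only" and "open" are said of these compounds alone.

Measured compounds:
Compound 1 `CN1CCC(c2ccc(Cl)cc2)C(C[S+]([O-])CCO)C1` gives 12 nM in an assay on isolated protein for inhibition of sodium-dependent dopamine transporter (Rattus norvegicus), read by radioligand binding; on this read-out lower numbers stand for stronger inhibition and higher numbers for weaker inhibition.
Compound 2 `CC(=O)OCC[S+]([O-])CC1CN(C)CCC1c1ccc(Cl)cc1` gives 9 nM in this assay.
Compound 3 `CN1CCC(c2ccc(Cl)cc2)C(C[S+]([O-])CC(=O)NO)C1` gives 55 nM in this assay.

Compound 3 carries the highest number of the three. The two steps leading into it read a 4.6-fold higher number from compound 1 to compound 3 (0.66 log units; beyond the scatter) and a 6.1-fold higher number from compound 2 to compound 3 (0.79 log units; beyond the scatter), both beyond the scatter, whereas the step of a 1.3-fold lower number from compound 1 to compound 2 (0.12 log units; within the scatter) separating the other two compounds stays within it. Compound 4 `CN1CCC(c2ccc(Cl)cc2)C(C[S+]([O-])CC(=O)N(C)C)C1` is not yet measured. It differs from compound 3 in one place: dimethylamino in place of hydroxyamino on a carbonyl carbon. Among the measured compounds shown here, no measured pair alters the group on this carbonyl carbon, so the only steps that bear on the change are those that exchanged the whole hydroxycarbamoyl arm for hydroxymethyl or acetoxymethyl, and both of these moved the number upward on arriving at compound 3 by a modest margin. Whether a dimethylcarbamoyl arm behaves like those two arms cannot be read from the data. The account therefore expects compound 4 to recover part of the ground, an expected step of a 2.2-fold lower number from compound 3 to compound 4 (0.34 log units; beyond the scatter), with wide uncertainty attached. The estimate for compound 4 in this assay is 25 nM, expected to fall between 8 nM and 80 nM.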

Compound 4, inhibition constant: 2880 nM
Estimate against measurement, compound 4: 120-fold (2.06 log units) below; the measured number lies above the stated range.
By their numbers in this assay, from the lowest: compounds 2 and 1 (each within the scatter of the next); then compound 3; then compound 4.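

In this assay, the group on the carbonyl carbon proves to be the decisive feature of this arm: dimethylamino in place of hydroxyamino gives a 52-fold higher number from compound 3 to compound 4 (1.72 log units; beyond the scatter) and is a large step, whereas the earlier exchanges of the whole arm were only modest. The same gap appears against the two arms that lack this carbonyl carbon, with a 240-fold higher number from compound 1 to compound 4 (2.38 log units; beyond the scatter) for dimethylcarbamoyl in place of hydroxymethyl and a 320-fold higher number from compound 2 to compound 4 (2.51 log units; beyond the scatter) for dimethylcarbamoyl in place of acetoxymethyl, so a carbonyl-bearing arm as such does not set the number, and the hydroxycarbamoyl arm stays far nearer to the other two arms than the dimethylcarbamoyl arm does. Nothing available on these compounds explains why this exchange costs so much.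

The compounds shown leave open whether the rise follows from the loss of the hydroxy group on that nitrogen or from the arrival of the two methyl groups, a question that a methylamino or methoxyamino group on the carbonyl carbon would address. Also open, on these data alone, is how a plain amino group there, or a carboxylic acid in place of the whole amide, would read.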